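One Ring Exchange on a Shared Core

This account rests on a few compounds, and the source may have more. Where it says the series, first, only, none or still open, it means among the compounds named here.

Compound 1 `Cc1n[nH]c(-c2ccccc2NCC2=NCCN2)n1`: < 5020 nM
Compound 2 `Cc1nc(-c2ccccc2NCC2=NCCN2)n(C)n1`: < 5020 nM

In an in vitro functional assay on cells (Fibroblast) for agonist activity at Alpha-1B adrenergic receptor (Homo sapiens) (a higher number here means that more compound is needed for the effect, a lower number that less compound is needed), compound 1 gives < 5020 nM, which is a limit of the assay rather than a number. Compound 2 likewise gives only a limit, < 5020 nM. Among the measured compounds shown here, the single measured step, a step that the two limits leave unreadable from compound 1 to compound 2, is therefore not readable in size, and the limit of < 5020 nM in this assay, at which 2 of the 2 values shown sit, shows both values resting at that limit. Compound 3 `Cn1ccnc1-c1ccccc1NCC1=NCCN1` differs from compound 1 by 1-methyl-1H-imidazol-2-yl in place of 3-methyl-1H-1,2,4-triazol-5-yl on an aromatic carbon. For the measured compounds named here, no measured step bears on this change, so no direction beyond the scatter can be expected. Compound 3 is estimated at 800 nM (from 80 nM to 5000 nM), an expected step that the limit leaves unreadable from compound 1 to compound 3.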

Compound 3, half-maximal effective concentration: 39.8 nM
Compound 3: the middle estimate sits 20-fold (1.30 log units) above what was measured, and the stated range ends above it.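

Among the compounds shown here, compound 1 is known only as a limit, and no new step to compound 3 can be read from it. The compounds shown leave open how large the difference between compound 1 and compound 3 really is in this assay.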